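This account rests on a few compounds, and the source may have more. Where it says the series, first, only, none or still open, it means among the compounds named here.

Measured so far:
- compound 1, `O=C(O)c1ccc(C(=O)/C(=C\c2ccc(F)c([N+](=O)[O-])c2)SCc2ccc(Cl)cc2)cc1`: < 1000 ug/mL
- compound 2, `O=C(O)c1ccc(C(=O)/C(=C\c2ccc(Br)c([N+](=O)[O-])c2)SCc2ccc(Br)cc2)cc1`: < 1000 ug/mL
- compound 3, `O=C(O)c1ccc(C(=O)/C(=C\c2ccc(F)cc2[N+](=O)[O-])SCc2ccc(Br)cc2)cc1`: < 1000 ug/mL

Of the compounds shown here, three built on one shared core have been tested in a physicochemical assay for solubility; a lower number here means a less soluble compound, a higher number a more soluble compound. For compound 1 the reading < 1000 ug/mL is a limit of the assay, not a number. For compound 2 the reading < 1000 ug/mL is likewise a limit. For compound 3 the reading < 1000 ug/mL is a limit as well. Compound 1 therefore stands only at a limit, and nothing separates it from its neighbours: the limit of < 1000 ug/mL in this assay, at which 3 of the 3 values shown sit. Among the compounds with values here, the one step between measured compounds, a step that the two limits leave unreadable from compound 2 to compound 3, cannot be sized for the same reason.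

Compound 4, `O=C(O)c1ccc(C(=O)/C(=C\c2ccc(F)c([N+](=O)[O-])c2)SCc2ccccc2)cc1`, differs from compound 1 by hydrogen in place of chloro on an aromatic carbon. Within the data shown here, no measured step touches this change, so the data give neither a size nor a direction for it. Since every measured compound sits at the limit, compound 4 is expected to sit there too, and a step that the limit leaves unreadable from compound 1 to compound 4 is expected to be no more than scatter. The estimate for compound 4 in this assay is 200 ug/mL, within a range from 20 ug/mL to 1000 ug/mL.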

Compound 4, solubility: < 1000 ug/mL
Compound 4 ended at the assay's limit; the forecaster's own chance of this, stated with the estimate: 85%; the middle value does not contradict the limit.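

Compound 4 gives < 1000 ug/mL, which is a limit and not a number. Within the data shown here, no step from compound 1 to compound 4 can be read, since both compounds stand at the same limit: the limit of < 1000 ug/mL in this assay, at which 4 of the 4 values shown sit. On these data alone, whether replacing chloro with hydrogen changes solubility, and in which direction, remains open.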